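Trading a 4-bromophenyl group for a 2,4-dichlorophenyl group

The compounds below may be only part of what the source reports. "The series", "measured", "known", "first", "only" and "open" are said of these compounds alone.

Of the compounds shown here, three sharing one core have been measured in a functional assay on HeLa cells (Homo sapiens) for cytotoxicity, read by MTT assay, with a stated time of 24 h; a higher number here means a weaker inhibitor, a lower number a stronger inhibitor. Compound 1 `COc1cc(/C=C2\CN(C)C/C(=C\c3ccccc3F)C2=O)cc(OC)c1OC`, carrying a 2-fluorophenyl group, gives 3220 nM. Compound 2 `COc1cc(/C=C2\CN(C)C/C(=C\c3cc(OC)c(OC)c(OC)c3)C2=O)cc(OC)c1`, with a 3,5-dimethoxyphenyl group at that place, gives 2300 nM. The two read alike: a 1.4-fold lower number from compound 1 to compound 2 (0.15 log units; within the scatter). Compound 3 `COc1cc(/C=C2\CN(C)C/C(=C\c3ccc(Br)cc3)C2=O)cc(OC)c1OC`, with a 4-bromophenyl group, gives 11900 nM, the highest number of the three and so the weakest inhibitor here.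

Compound 4 `COc1cc(/C=C2\CN(C)C/C(=C\c3ccc(Cl)cc3Cl)C2=O)cc(OC)c1OC` is still unmeasured and differs from compound 3 in one group: 2,4-dichlorophenyl in place of 4-bromophenyl on a double-bonded chain carbon bound to a double-bonded ring carbon.

Two measured steps at this same place bear on the change: a 3.7-fold higher number from compound 1 to compound 3 (0.57 log units; beyond the scatter), and a 5.2-fold higher number from compound 2 to compound 3 (0.71 log units; beyond the scatter). Both are modest, and both rise on arriving at the 4-bromophenyl group. In its name, the 2,4-dichlorophenyl group echoes both the 2-fluorophenyl group of compound 1, at 3220 nM, and the 4-bromophenyl group of compound 3, at 11900 nM. Among the compounds with values here, no measured compound carries chlorine, so this guide is loose.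

A modest fall in the number is therefore expected, and the estimated step is a 2.2-fold lower number from compound 3 to compound 4 (0.34 log units; beyond the scatter). For compound 4 the estimated value is 5500 nM, with an expected range from 2000 nM to 14000 nM.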

Compound 4, half-maximal inhibitory concentration: > 20000 nM
Compound 4 ended at the assay's limit; the forecaster's own chance of this, stated with the estimate: 1%; middle value at least 3.6-fold (0.56 log units) away from the limit.
By their numbers in this assay, from the lowest: compounds 2 and 1 (each within the scatter of the next); then compound 3. At a limit, above all of these: compound 4.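

Compound 4 stands at a limit in this assay, not at a number: the limit of > 20000 nM in this assay, at which 1 of the 4 values shown sits.

Against its nearest neighbour the result sets only a floor, an at least 1.6-fold higher number from compound 3 to compound 4 (0.22 log units; that floor lies within the scatter), so this pair alone cannot show whether swapping the 4-bromophenyl group for the 2,4-dichlorophenyl group changes the reading much or little. The comparisons with the two stronger compounds are firmer, with an at least 6.2-fold higher number from compound 1 to compound 4 (0.79 log units; beyond the scatter) and an at least 8.6-fold higher number from compound 2 to compound 4 (0.93 log units; beyond the scatter), and they show that this place also tolerates the 2,4-dichlorophenyl group poorly, with both halogen-bearing groups of compounds 3 and 4 reading weaker than the 3,5-dimethoxyphenyl group of compound 2, although compound 1 goes against any simple rule that a halogen weakens, since its 2-fluorophenyl group reads alike with compound 2.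

From the compounds shown here alone, how far compound 4 really lies beyond compound 3 stays unknown, since a limit gives no position on the scale. Also open, going by these compounds, is how a 4-chlorophenyl group, or a phenyl ring carrying an amine or a carboxylic acid, would read at this place, which would help separate the effect of the chlorine atoms from that of the ring's other features.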